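The compounds below may be only part of what the source reports. "The series", "measured", "known", "first", "only" and "open" are said of these compounds alone.

Measured compounds:
compound 1, `O=C(NO)c1ccc(CNCc2nnnn2Cc2ccccc2)cc1`, gives 100 nM in an assay on isolated protein for inhibition of protein deacetylase HDAC6 (Homo sapiens), read by fluorescence, with a stated time of 90 min; a lower number here means a stronger inhibitor, a higher number a weaker inhibitor
compound 2, `CC(C)c1ccc(C(=O)N(Cc2ccc(C(=O)NO)cc2)Cc2nnnn2Cc2ccccc2)cc1`, gives 320 nM in this assay

For the measured compounds named here, compound 1 holds the lower of the two numbers, and compound 2 is its only neighbour, set apart by a 3.2-fold higher number from compound 1 to compound 2 (0.51 log units; beyond the scatter). Compound 3, `CCCCC(NCc1ccc(C(=O)NO)cc1)c1nnnn1Cc1ccccc1`, differs from compound 1 by butyl in place of hydrogen on a saturated chain carbon bound to an amine nitrogen and an aromatic carbon. Going by the values given here, the one measured step, from compound 1 to compound 2, altered the amine nitrogen, not this carbon, and was modest; it offers only a loose guide. For compound 3 a small step, if any, is expected, a 1.6-fold higher number from compound 1 to compound 3 (0.20 log units; within the scatter), giving an estimate of 160 nM with a range from 50 nM to 500 nM.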

Compound 3, half-maximal inhibitory concentration: 120 nM
For compound 3 the middle estimate is 1.3-fold (0.12 log units) above the measured one; measured number inside the range.
By their numbers in this assay, from the lowest: compounds 1 and 3 (each within the scatter of the next); then compound 2.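

The earlier compounds shown here left this carbon unchanged, and butyl placed on it gives a 1.2-fold higher number from compound 1 to compound 3 (0.08 log units; within the scatter) in this assay. At this carbon, then, a butyl chain leaves the number within the scatter, whereas the change on the amine nitrogen gave a 3.2-fold higher number from compound 1 to compound 2 (0.51 log units; beyond the scatter). No supporting measurement bears on why this is so.

A single group at one carbon cannot show how far this holds. Going by these compounds, whether an amine, a carboxylic acid or a longer chain at the same carbon would behave like butyl stays open.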